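Bromo in Place of Nitro, Starting from Two Limits

The source may report more compounds than this note shows. Statements on the series, on what has been measured and on what is new or still open speak of the compounds shown alone.

Compound 1, `O=C1c2cccc(F)c2C(=O)C1(O)O`, in an assay on isolated protein for inhibition of carbonic anhydrase 4 (Homo sapiens), read by stopped-flow, with a stated time of 15 min; on this read-out lower numbers stand for stronger inhibition and higher numbers for weaker inhibition: > 100000 nM, a limit of the assay.
Compound 2, `O=C1c2cccc([N+](=O)[O-])c2C(=O)C1(O)O`, in this assay: > 100000 nM, likewise a limit of the assay.

Compound 2 stands only at a limit in this assay, with no number placed on the scale. Within the data shown here, the single measured step, a step that the two limits leave unreadable from compound 1 to compound 2, cannot be given a size because both of its ends sit at the limit of > 100000 nM in this assay, at which 2 of the 2 values shown sit. Nothing in the measured data therefore shows whether exchanging one small group on the aromatic carbon moves the inhibition at all.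

Compound 3, `O=C1c2cccc(Br)c2C(=O)C1(O)O`, differs from compound 2 by bromo in place of nitro on an aromatic carbon. No measured step bears on this particular change; the only step shown, from fluoro to nitro, stayed unreadable. With both neighbours at the limit, there is no basis for expecting compound 3 to reach a readable number in this assay.

Compound 3 is expected at about 200000 nM, within a range from 50000 nM to 1000000 nM, most probably reported again only as a limit. The estimated step from compound 2 to compound 3 is a step that the limit leaves unreadable from compound 2 to compound 3, expected to lie within the scatter.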

Compound 3, inhibition constant: > 100000 nM
Compound 3 gave a limit, no number; the forecaster's own chance of this, stated with the estimate: 80%; the middle value does not contradict the limit.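

Compound 3 is again only a limit in this assay, so the steps among compound 1, compound 2 and compound 3 cannot be read: the limit of > 100000 nM in this assay, at which 3 of the 3 values shown sit.

The compounds shown leave open whether any group on this aromatic carbon of the shared core can give a readable inhibition, and how fluoro, nitro and bromo would rank.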